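The compounds below may be only part of what the source reports. "The series", "measured", "known", "first", "only" and "open" are said of these compounds alone.

For the measured compounds named here, compound 1 `COCc1ncc2cnnc(SC)n12` is one of two compounds measured in a functional assay for inhibition, with Homo sapiens as the target; on this read-out lower numbers stand for stronger inhibition and higher numbers for weaker inhibition. In this assay compound 1 gives only a limit of the assay, > 48000 nM. Compound 2 `COCc1ncc2cnnc(O)n12` carries hydroxy in place of methylsulfanyl on an aromatic carbon. In this assay compound 2 likewise gives only a limit, > 48000 nM. Going by the values given here, the single measured step, a step that the two limits leave unreadable from compound 1 to compound 2, therefore cannot be read; the whole of the evidence is the limit of > 48000 nM in this assay, at which 2 of the 2 values shown sit. Compound 3 `CSc1nncc2cnc(C)n12` differs from compound 1 by hydrogen in place of methoxy on a saturated chain carbon bound to an aromatic carbon. Among the compounds with values here, no measured step concerns this change, and the one comparison available is unreadable, so neither a size nor a direction can be drawn from it, while compound 1 itself stands at a limit. Compound 3 is expected to stay at that same limit, so the step that the limit leaves unreadable from compound 1 to compound 3 is estimated as no readable change. The estimate for compound 3 in this assay is 70000 nM, with a range from 20000 nM to 250000 nM.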

Compound 3, half-maximal inhibitory concentration: > 48000 nM
Compound 3: a limit, no number; the forecaster's own chance of this, stated with the estimate: 85%; the middle value lies beyond the limit too.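

For the compounds shown here, compound 3 stays at a limit, as compound 1 does, so no step from compound 1 to compound 3 can be read, and none can be read among the other compounds either. The compounds shown leave open at what concentration, if any, any of them inhibits in this assay: the limit of > 48000 nM in this assay, at which 3 of the 3 values shown sit.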